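Removing the ring methyl from compound 1

This account rests on a few compounds, and the source may have more. Where it says the series, first, only, none or still open, it means among the compounds named here.

In a functional assay on IGROV-1 cells (Homo sapiens) for inhibition (on this read-out lower numbers stand for stronger inhibition of growth and higher numbers for weaker inhibition of growth), compound 1 `C=C1CC(Cn2cc(C)c(=O)[nH]c2=O)(c2ccc(-c3ccccc3)cc2)OC1=O` gives 1910 nM, the lowest of the two numbers seen so far. Its nearest neighbour is compound 2 `C=C1CC(Cn2cc(C)c(=O)[nH]c2=O)(c2ccc(F)cc2)OC1=O`, which in this assay gives 5500 nM; the step of a 2.9-fold higher number from compound 1 to compound 2 (0.46 log units; beyond the scatter) is a modest one and concerns only the aryl substituent. Compound 3 `C=C1CC(Cn2ccc(=O)[nH]c2=O)(c2ccc(-c3ccccc3)cc2)OC1=O` is not yet measured in this assay. It differs from compound 1 by hydrogen in place of methyl on an aromatic carbon, on an aromatic carbon of a six-membered aromatic ring with two nitrogens. Among the compounds with values here, no measured step touches this part of the shared core, so the only step known, from compound 1 to compound 2, gives no direct guide here. With nothing to indicate a change in either direction, the step from compound 1 to compound 3 is expected to stay within the scatter, a 1.3-fold higher number from compound 1 to compound 3 (0.12 log units; within the scatter). For compound 3 the estimate in this assay is 2500 nM, within a range of 1000 nM to 6500 nM.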

Compound 3, concentration for 50% growth inhibition: 708 nM
Estimate against measurement, compound 3: 3.5-fold (0.55 log units) above; measured number below the stated range.
By their numbers in this assay, from the lowest: compound 3; then compound 1; then compound 2.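

Working notes on the methyl position: in this assay, the first change to this part of the shared core gives a 2.7-fold lower number from compound 1 to compound 3 (0.43 log units; beyond the scatter) and so lowers the number. The methyl on this aromatic carbon is therefore not needed for growth inhibition in the biphenyl-bearing compound 1, and hydrogen is the better of the two groups seen here. Within the data shown here, this position also affects the read-out, with a modest step of the same printed class as a 2.9-fold higher number from compound 1 to compound 2 (0.46 log units; beyond the scatter) at the aryl substituent, so the aryl substituent is no longer the only known point of change; no measurement available here explains the shift.

The compounds shown leave open whether hydrogen in place of methyl has the same effect when the aryl substituent is the fluoro group of compound 2. They also leave open how ethyl, an amine or a carboxylic acid on this carbon would compare with hydrogen and methyl.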